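From 3-fluorophenyl to phenyl: a step at the limit

The source may hold more compounds than are shown below. What is called first, only, known or untested is meant among the compounds shown, and "the series" means these compounds.

Compound 1 `CCOC(=O)c1c(-c2ccc(C(F)(F)F)cc2)[nH]c2cccc(OC)c2c1=O` gives 22000 nM
Compound 2 `CCOC(=O)c1c(-c2ccc(Cl)cc2)[nH]c2cccc(OC)c2c1=O` gives > 100000 nM (a limit, not a number)
Compound 3 `CCOC(=O)c1c(-c2cccc(F)c2)[nH]c2cccc(OC)c2c1=O` gives > 100000 nM (a limit, not a number)

All three compounds share one core and were read in a physicochemical assay for solubility, in phosphate buffer, at pH 7.4; a higher number here means a more soluble compound, a lower number a less soluble compound. Compound 3 stands at > 100000 nM, which is a limit of the assay and not a number. Compound 3 thus shares (the limit of > 100000 nM in this assay, at which 2 of the 3 values shown sit), and no number orders it against compound 2.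

Compound 4 `CCOC(=O)c1c(-c2ccccc2)[nH]c2cccc(OC)c2c1=O` follows from compound 3 with hydrogen in place of fluoro on an aromatic carbon, meta to a large group: hydrogen in place of fluoro on an aromatic carbon. The same difference reads 3-fluorophenyl to phenyl.

Going by the values given here, no measured step makes this exact exchange. The closest in kind is a step that the two limits leave unreadable from compound 2 to compound 3, and it gives no size. Among the compounds with values here, the only readable step is an at least 4.5-fold higher number from compound 1 to compound 2 (0.65 log units; beyond the scatter), which is a different exchange, chloro in place of trifluoromethyl. With compound 3 at > 100000 nM as the starting limit, compound 4 is expected to read at or close to that limit too. The expected size is an at least 1.1-fold lower number from compound 3 to compound 4 (0.04 log units; that floor lies within the scatter), with no step beyond the scatter in either direction. For compound 4 the estimated value is 90000 nM, with an expected range from 35000 nM to 150000 nM.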

Compound 4, solubility: > 100000 nM
Compound 4 gave a limit, no number; the forecaster's own chance of this, stated with the estimate: 60%; middle value at least 1.1-fold (0.04 log units) away from the limit.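

In this assay compound 4 gives > 100000 nM, which is a limit of the assay and not a number. The steps among compound 2, compound 3 and compound 4 cannot be read, so hydrogen in place of fluoro has no measurable size here; what is new is that the plain phenyl compound sits at the same limit, which the earlier compounds had shown only with chloro and with 3-fluorophenyl. The one readable step is an at least 4.5-fold higher number from compound 1 to compound 4 (0.65 log units; beyond the scatter), where trifluoromethyl gives way to hydrogen, and its printed floor is the same as that of an at least 4.5-fold higher number from compound 1 to compound 2 (0.65 log units; beyond the scatter), so among the compounds shown a number appears only with trifluoromethyl: the limit of > 100000 nM in this assay, at which 3 of the 4 values shown sit.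

On these data alone, how compound 2, compound 3 and compound 4 order against one another stays open, as does the true size of their steps from compound 1. Also open, as far as these compounds go, is whether an amine, a carboxylic acid or a longer chain on that aromatic ring would give a number, and on which side of the limit it would fall.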